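This account rests on a few compounds, and the source may have more. Where it says the series, first, only, none or still open, it means among the compounds named here.

Measured in a functional assay on KB cells (Homo sapiens) for antiproliferative activity, read by sulforhodamine B assay, with a stated time of 3 days; a higher number here means that more compound is needed for the effect, a lower number that less compound is needed:
- compound 1 `CCC1=C(O)c2c(oc(-c3ccc(C)cc3)cc2=O)C(CC)(CC)C1=O`: 39.2 uM
- compound 2 `CCC1=C(O)c2c(oc(-c3ccc(SC)cc3)cc2=O)C(CC)(CC)C1=O`: > 52.1 uM (a limit)
- compound 3 `CCC1=C(O)c2c(oc(-c3ccc(C)cc3C)cc2=O)C(CC)(CC)C1=O`: 41.2 uM

Not yet measured: compound 4 `CCC1=C(O)c2c(oc(-c3cc(C)c(C)cc3C)cc2=O)C(CC)(CC)C1=O`.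

Compound 3, at 41.2 uM, lies within the scatter of compound 1, at 39.2 uM. Compound 2 offers no number for comparison, as its > 52.1 uM is a limit.

The change to compound 4 is methyl in place of hydrogen on an aromatic carbon, taking 2,4-dimethylphenyl to 2,4,5-trimethylphenyl. Among the compounds with values here, the closest precedent is the same kind of change, methyl in place of hydrogen on an aromatic carbon: a 1.1-fold higher number from compound 1 to compound 3 (0.02 log units; within the scatter). The step to compound 2 is less closely related: an at least 1.3-fold higher number from compound 1 to compound 2 (0.12 log units; that floor lies within the scatter). In this assay, no step beyond the scatter is therefore expected: a 1.0-fold lower number from compound 3 to compound 4 (0.00 log units; within the scatter). The estimate for compound 4 is 41 uM, with an expected range of 23 uM to 62 uM.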

Compound 4, concentration for half-maximal effect: 8.2 uM
Estimate against measurement, compound 4: 5.0-fold (0.70 log units) above; measured number outside the range, below it.
By their numbers in this assay, from the lowest: compound 4; then compounds 1 and 3 (each within the scatter of the next). At a limit, above all of these: compound 2.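

In this assay, methyl in place of hydrogen is not a neutral change at this position, ortho to a methyl group and para to a methyl group: the step is a 5.0-fold lower number from compound 3 to compound 4 (0.70 log units; beyond the scatter), whereas the same kind of change elsewhere on the ring gave a 1.1-fold higher number from compound 1 to compound 3 (0.02 log units; within the scatter). The 2,4,5-trimethylphenyl group also stands apart from 4-methylphenyl, with a 4.8-fold lower number from compound 1 to compound 4 (0.68 log units; beyond the scatter), and from 4-(methylsulfanyl)phenyl, with an at least 6.3-fold lower number from compound 2 to compound 4 (0.80 log units; beyond the scatter), a floor, as compound 2 carries a limit. Nothing shown accounts for the gain.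

On these data alone, whether chlorine, a methoxy group or a longer chain at this position would do the same stays open. So does whether this methyl gives the gain without the other two methyl groups.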